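Amide to amine at the thiophene side chain

The source may report more compounds than this note shows. Statements on the series, on what has been measured and on what is new or still open speak of the compounds shown alone.

Measured compounds:
compound 1 `CCN1CCN(c2cccc3c2CN([C@H](CCCNC(=O)c2c(C)n[nH]c2C)c2ccc(OC)c(OC)c2)C3=O)CC1`, 130 nM
compound 2 `CCN1CCN(c2cccc3c2CN([C@H](CCCNC(=O)c2cccs2)c2ccc(OC)c(OC)c2)C3=O)CC1`, 140 nM

Both were tested in a functional assay on RMS13 cells for antagonist activity at Urotensin-2 receptor (Homo sapiens), read by FLIPR and calcium flux, with a stated time of 1 h; a higher number here means a weaker inhibitor, a lower number a stronger inhibitor. Among the measured compounds shown here, compound 2 gives 140 nM, which is the higher of the two numbers, but its only neighbour, compound 1, lies within the scatter of it: a 1.1-fold higher number from compound 1 to compound 2 (0.03 log units; within the scatter).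

Compound 3 `CCN1CCN(c2cccc3c2CN([C@H](CCCNCc2cccs2)c2ccc(OC)c(OC)c2)C3=O)CC1` differs from compound 2 in one place: (thiophen-2-yl)methyl in place of (thiophen-2-yl)carbonyl on an amine nitrogen. For the measured compounds named here, the one measured step swaps the aromatic ring that sits on the carbonyl, not the carbonyl itself, so it does not bear on this change; no step in the data compares an amide with the corresponding amine. The expectation therefore rests on nothing measured, and a moderate weakening with a wide range is estimated for compound 3: a 2.1-fold higher number from compound 2 to compound 3 (0.33 log units; beyond the scatter) in this assay . The estimated value for compound 3 is 300 nM, within a range from 80 nM to 1500 nM.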

Compound 3, half-maximal inhibitory concentration: 59 nM
Beside the measured number, compound 3's estimate is 5.1-fold (0.71 log units) above it, and the stated range ends above it.
By their numbers in this assay, from the lowest: compound 3; then compounds 1 and 2 (each within the scatter of the next).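

In this assay the carbonyl of the side chain turns out not to be required: (thiophen-2-yl)methyl in place of (thiophen-2-yl)carbonyl on the amine nitrogen gives a 2.4-fold lower number from compound 2 to compound 3 (0.38 log units; beyond the scatter). The amine also separates from the pyrazole amide, with a 2.2-fold lower number from compound 1 to compound 3 (0.34 log units; beyond the scatter). Among the compounds shown, changing the carbonyl to a methylene moves the number beyond the scatter, whereas exchanging the ring on the carbonyl does not, and nothing measured here accounts for the gain.

Going by these compounds, it remains open whether (3,5-dimethyl-1H-pyrazol-4-yl)methyl on the same amine nitrogen would behave as the thiophene does. Also open, on these data alone, are how a phenyl ring in place of the thiophene, or a methyl group added on that amine nitrogen, would read.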